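Pyridin-4-yl for 3-methylphenyl on the benzylic carbon

The compounds below may be only part of what the source reports. "The series", "measured", "known", "first", "only" and "open" are said of these compounds alone.

Measured so far:
compound 1, `O=C(CNC(=O)c1ccsc1)NC(c1ccccc1)c1ccc(Cl)cc1`, 89 nM
compound 2, `Cc1cccc(C(NC(=O)CNC(=O)c2ccc(F)cc2)c2ccccc2)c1`, 56 nM
compound 3, `COc1ccc(C(NC(=O)CNC(=O)c2ccc(F)cc2)c2ccc(OC)cc2)cc1`, 6630 nM

In an assay for inhibition of sodium- and chloride-dependent glycine transporter 1 (Homo sapiens) (on this read-out lower numbers stand for an effect already at smaller amounts and higher numbers for an effect only at larger amounts of compound), compound 2 gives 56 nM, the lowest of the three numbers, though the gap to compound 1 is within the scatter and only compound 3 sits clearly higher. Compound 4, `O=C(CNC(=O)c1ccc(F)cc1)NC(c1ccccc1)c1ccncc1`, has not been measured. The change from compound 2 is pyridin-4-yl in place of 3-methylphenyl on a saturated chain carbon bound to an amide-type nitrogen and an aromatic carbon. For the measured compounds named here, no pair of measured compounds isolates this change; the values of compound 2 and compound 3 show only that a change on this carbon can shift the number a great deal. A step toward higher numbers, beyond the scatter, is expected here. Compound 4 is expected to give 300 nM, with a range of 80 nM to 1500 nM. The expected step is a 5.4-fold higher number from compound 2 to compound 4 (0.73 log units; beyond the scatter).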

Compound 4, half-maximal effective concentration: 730 nM
Beside the measured number, compound 4's estimate is 2.4-fold (0.39 log units) below it; the measured number falls inside the stated range.
By their numbers in this assay, from the lowest: compounds 2 and 1 (each within the scatter of the next); then compound 4; then compound 3.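

In this assay, for the compounds shown here, pyridin-4-yl in place of 3-methylphenyl on this saturated chain carbon gives a 13-fold higher number from compound 2 to compound 4 (1.12 log units; beyond the scatter) and is the first step that isolates a single change at this position. This carbon therefore does not treat these two six-membered aromatic rings alike, and the exchange of 3-methylphenyl for a ring with one hetero atom and one hydrogen-bond acceptor is enough to move the number beyond the scatter. Nothing measured here accounts for the step. Ring nitrogen and lost methyl change together, so their separate shares remain open. Also open, from the compounds shown here alone, is how pyridin-3-yl or a saturated piperidin-4-yl would read on this carbon.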